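Aryl swap on compound 3: cytotoxicity notes

The compounds below may be only part of what the source reports. "The series", "measured", "known", "first", "only" and "open" are said of these compounds alone.

The read-out is an ADME assay on MT2 cells (Homo sapiens) for cytotoxicity, read by XTT assay, with a stated time of 4 days; on this read-out higher numbers stand for lower toxicity in this test and lower numbers for higher toxicity in this test. Compound 1 `Cc1nc(C(NC(=O)C(=O)Nc2ccc(Cl)cc2)C2CCCCN2)sc1CO` reaches only a limit, > 108000 nM. Compound 2 `Cc1nc(C(NC(=O)C(=O)Nc2ccc(Cl)c(F)c2)C2CCCCN2)sc1CO` gives 77800 nM. Compound 3 `Cc1ccc(NC(=O)C(=O)NC(c2nc(C)c(CO)s2)C2CCCCN2)cc1F` also reaches only a limit, > 88000 nM, so its true position in this assay is not known.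

Compound 4 `CC(=O)c1ccc(NC(=O)C(=O)NC(c2nc(C)c(CO)s2)C2CCCCN2)cc1` carries 4-acetylphenyl in place of 3-fluoro-4-methylphenyl on an amide-type nitrogen. Two measured steps in the same part of the structure offer a guide: an at least 1.3-fold lower number from compound 1 to compound 2 (0.14 log units; that floor lies within the scatter), and an at least 1.1-fold higher number from compound 2 to compound 3 (0.05 log units; that floor lies within the scatter). Both floors lie within the scatter, while a step that the two limits leave unreadable from compound 1 to compound 3 cannot be sized. No step beyond the scatter is therefore expected in either direction, and the expected change is an at least 1.0-fold lower number from compound 3 to compound 4 (0.01 log units; that floor lies within the scatter). Compound 4 is estimated at 85000 nM, within a range of 40000 nM to 150000 nM.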

Compound 4, half-maximal cytotoxic concentration: > 107000 nM
Compound 4: no number, only a limit (the forecaster's own chance of this, stated with the estimate: 55%); middle value at least 1.2-fold (0.09 log units) from the limit.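

Compound 4 also reaches only a limit in this assay: the limit of > 107000 nM in this assay, at which 1 of the 4 values shown sits.

With this change, 4-acetylphenyl on the amide-type nitrogen joins 4-chlorophenyl and 3-fluoro-4-methylphenyl as groups that give a limit rather than a number. Among the compounds shown here, the one readable step is an at least 1.3-fold higher number from compound 2 to compound 4 (0.13 log units; that floor lies within the scatter), and the steps among compounds 1, 3 and 4 cannot be read.

Where the true values of compounds 1, 3 and 4 lie stays open. Also open, going by these compounds, is whether an amine or a carboxylic acid in place of the acetyl group would give a measured number.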